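Swapping the aryl group on the pyridazinone nitrogen

A few compounds are considered here, and "the series" means these few. Any claim that something is new, unique, unknown or untested is made for them only; others in the source may bear on it.

Measured compounds:
- compound 1, `CNC(=O)c1cc(Oc2ccc(NC(=O)c3nn(-c4ccccc4OC(F)(F)F)c(=O)cc3C)cc2F)ccn1`, > 40000 nM
- compound 2, `Cc1cc(=O)n(-c2ccccc2C(F)(F)F)nc1C(=O)Nc1ccc(Oc2ncnc3ccsc23)cc1`, 8850 nM

In a functional assay on A549 cells (Homo sapiens) for cytotoxicity, read by MTT assay, with a stated time of 72 h (on this read-out higher numbers stand for weaker inhibition and lower numbers for stronger inhibition), compound 1 returns only a limit, > 40000 nM, and no number. In this assay, for the measured compounds named here, compound 2 gives 8850 nM, which is the only actual number among the two values shown. The other value, that of compound 1, is a limit (the limit of > 40000 nM in this assay, at which 1 of the 2 values shown sits).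

Compound 3, `Cc1cc(=O)n(-c2cccc(F)c2)nc1C(=O)Nc1ccc(Oc2ncnc3ccsc23)cc1`, has not been measured. It differs from compound 2 in one place: 3-fluorophenyl in place of 2-(trifluoromethyl)phenyl on an aromatic nitrogen. No step between two measured compounds covers this kind of exchange, so there is no shown precedent to lean on. The author expects the change from compound 2 to compound 3 to stay within the scatter, or at most to weaken inhibition slightly, so that a 1.2-fold higher number from compound 2 to compound 3 (0.09 log units; within the scatter) is expected. On that basis compound 3 is estimated at 11000 nM in this assay, with a range from 4000 nM to 32000 nM.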

Compound 3, half-maximal inhibitory concentration: 9540 nM
Compound 3: middle estimate off by 1.2-fold (0.06 log units), on the high side; low and high end bracket the measured number.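

In this assay, placing 3-fluorophenyl in place of 2-(trifluoromethyl)phenyl on the aromatic nitrogen gives a 1.1-fold higher number from compound 2 to compound 3 (0.03 log units; within the scatter). This is the first step shown at this position, and it indicates that, for this pair, the read-out does not separate the two aryl groups, although the entering group has fewer heavy atoms and fluorines and carries its substituent at a different ring position. Nothing shown bears on why the two compounds read alike.

All the aryl groups shown on this nitrogen are phenyl rings carrying fluorine, so it remains open how the read-out would respond to a phenyl ring bearing an amine or a carboxylic acid, or to a simple alkyl chain there. For the compounds shown here, it is also open whether this exchange would read the same on another core, since only one pair covers it.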